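Lengthening the hydroxycarbamoyl chain of compound 2

This account rests on a few compounds, and the source may have more. Where it says the series, first, only, none or still open, it means among the compounds named here.

In a functional assay on Hep 3B2 cells (Homo sapiens) for antiproliferative activity, read by sulforhodamine B assay, with a stated time of 48 h (on this read-out higher numbers stand for weaker inhibition of growth and lower numbers for stronger inhibition of growth), compound 1 `CC(C)CCc1c(OCCCCCC(=O)NO)ccc2ccc(=O)oc12` gives 800 nM as a measured number. Compound 2 `CC(C)CCc1c(OCCCCCC(=O)NO)ccc2c1OC(=O)CC2` gives > 30000 nM in this assay, and this is a limit of the assay, not a number.

Compound 3 `CC(C)CCc1c(OCCCCCCCC(=O)NO)ccc2c1OC(=O)CC2` has not yet been measured. It differs from compound 2 in one place: 2-(hydroxycarbamoyl)ethyl in place of hydroxycarbamoyl on a saturated chain carbon, five bonds along the chain from an oxygen on an aromatic ring. Going by the values given here, no measured step shows what this change does in this assay, so a modest shift toward stronger inhibition of growth is expected, and compound 3 may yet stay at the limit. The expected change is an at least 2.5-fold lower number from compound 2 to compound 3 (0.39 log units; beyond the scatter) on this estimate. Compound 3 is estimated at 12000 nM, with an expected range from 3000 nM to 30000 nM as its bounds.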

Compound 3, concentration for 50% growth inhibition: > 30000 nM
Compound 3 gave a limit, no number (the forecaster's own chance of this, stated with the estimate: 40%); at least 2.5-fold (0.39 log units) between middle value and limit.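

Compound 2 and compound 3 both sit at a limit rather than a number, so no step between them can be read: the limit of > 30000 nM in this assay, at which 2 of the 3 values shown sit.

The compounds shown leave open whether 2-(hydroxycarbamoyl)ethyl in place of hydroxycarbamoyl changes growth inhibition at all.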